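Changing the capping group on a weak chromobox binder

A few compounds are considered here, and "the series" means these few. Any claim that something is new, unique, unknown or untested is made for them only; others in the source may bear on it.

Compound 1 `CC(C)C[C@H](NC(=O)[C@H](C)NC(=O)c1ccccc1)C(=O)N[C@@H](CCCC[N+](C)(C)C)C(=O)N[C@@H](CO)C(N)=O`: 57000 nM
Compound 2 `CC(C)C[C@H](NC(=O)[C@H](C)NC(=O)CCc1ccccc1)C(=O)N[C@@H](CCCC[N+](C)(C)C)C(=O)N[C@@H](CO)C(N)=O`: 26000 nM
Compound 3 `CC(C)C[C@H](NC(=O)[C@H](C)NC(=O)OCc1ccccc1)C(=O)N[C@@H](CCCC[N+](C)(C)C)C(=O)N[C@@H](CO)C(N)=O`: 58000 nM

These three compounds share one peptide-like core and differ only in the group on the carbonyl carbon at one end. In an assay on isolated protein for displacement of a labelled ligand from Chromobox protein homolog 7 (Homo sapiens), read by fluorescence polarization, with a stated time of 15 min (on this read-out lower numbers stand for stronger inhibition and higher numbers for weaker inhibition), compound 1 stands second highest of the three numbers, close to compound 3 and further from compound 2. The measured steps there are a 2.2-fold lower number from compound 1 to compound 2 (0.34 log units; beyond the scatter), a 1.0-fold higher number from compound 1 to compound 3 (0.01 log units; within the scatter) and a 2.2-fold higher number from compound 2 to compound 3 (0.35 log units; beyond the scatter), so swapping this end group has so far moved the number only modestly in either direction.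

Compound 4 `CC(C)C[C@H](NC(=O)[C@H](C)NCc1ccc(C(=O)O)cc1)C(=O)N[C@@H](CCCC[N+](C)(C)C)C(=O)N[C@@H](CO)C(N)=O` takes the change one step further: 4-carboxybenzyl in place of benzoyl on an amine nitrogen. Within the data shown here, none of the measured steps exchanges a benzoyl for a benzyl-type group with a carboxylic acid, so the direction is uncertain; the earlier steps suggest a modest shift at most. Compound 4 is therefore expected to give about 60000 nM, somewhere between 20000 nM and 200000 nM, which means an estimated step of a 1.1-fold higher number from compound 1 to compound 4 (0.02 log units; within the scatter).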

Compound 4, half-maximal inhibitory concentration: > 2000000 nM
Compound 4 gave a limit, no number (the forecaster's own chance of this, stated with the estimate: 30%); middle value at least 33-fold (1.52 log units) from the limit.
By their numbers in this assay, from the lowest: compound 2; then compounds 1 and 3 (each within the scatter of the next). At a limit, above all of these: compound 4.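

Compound 4 gave a limit of the assay and not a number: the limit of > 2000000 nM in this assay, at which 1 of the 4 values shown sits. The three earlier end groups stayed close together, whereas 4-carboxybenzyl on this amine nitrogen gives an at least 35-fold higher number from compound 1 to compound 4 (1.54 log units; beyond the scatter) and an at least 34-fold higher number from compound 3 to compound 4 (1.53 log units; beyond the scatter) and an at least 76-fold higher number from compound 2 to compound 4 (1.88 log units; beyond the scatter) as its steps. Among these compounds, this end of the molecule is therefore far less tolerant of change than the earlier compounds suggested.

Compound 4 both loses the carbonyl on the nitrogen and gains a carboxylic acid, so the shown compounds cannot separate the two changes. A plain benzyl on the same nitrogen, or a 4-carboxybenzoyl group, would tell them apart.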